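A Ring Methyl on the Lowest of Three Compounds

This account rests on a few compounds, and the source may have more. Where it says the series, first, only, none or still open, it means among the compounds named here.

In a functional assay (L1210 cells) for inhibition, with Mus musculus as the target (on this read-out lower numbers stand for stronger inhibition and higher numbers for weaker inhibition), compound 1 `C#CCN(Cc1ccc2nc(C)nc(O)c2c1)c1ccc(C(=O)N[C@@H](CCC(=O)O)C(=O)N2CCCC2C(=O)O)cc1` gives 3100 nM, compound 3 `C#CCN(Cc1ccc2nc(C)nc(O)c2c1)c1ccc(C(=O)N[C@@H](CCC(=O)O)C(=O)NC(C)(C)C(=O)O)cc1` gives 2500 nM and compound 2 `C#CCN(Cc1ccc2nc(C)nc(O)c2c1)c1ccc(C(=O)N[C@@H](CCC(=O)O)C(=O)N(C)[C@@H](CCC(=O)O)C(=O)O)cc1` gives 240 nM, the lowest number of the three. Compound 4 `C#CCN(Cc1cc2c(O)nc(C)nc2cc1C)c1ccc(C(=O)N[C@@H](CCC(=O)O)C(=O)N(C)[C@@H](CCC(=O)O)C(=O)O)cc1` keeps the carbonyl-linked end group of compound 2 and alters the shared core: methyl in place of hydrogen on an aromatic carbon. Among the compounds with values here, the measured steps of a 13-fold lower number from compound 1 to compound 2 (1.11 log units; beyond the scatter) and a 10-fold higher number from compound 2 to compound 3 (1.02 log units; beyond the scatter) are large, but they change only that end group. So does a 1.2-fold lower number from compound 1 to compound 3 (0.09 log units; within the scatter), which stays within the scatter. None of them touches the core, so they give no size for this change. In this assay, no shift beyond the scatter is therefore expected. The estimated step is a 1.6-fold lower number from compound 2 to compound 4 (0.20 log units; within the scatter). The estimated value for compound 4 is 150 nM, within a range of 40 nM to 500 nM.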

Compound 4, half-maximal inhibitory concentration: 220 nM
Beside the measured number, compound 4's estimate is 1.5-fold (0.17 log units) below it; measured number inside the range.
By their numbers in this assay, from the lowest: compounds 4 and 2 (each within the scatter of the next); then compounds 3 and 1 (each within the scatter of the next).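

In this assay, methyl in place of hydrogen on this aromatic carbon, ortho to a large group, gives a 1.1-fold lower number from compound 2 to compound 4 (0.04 log units; within the scatter) and so cannot be told from the scatter. Within the data shown here, the earlier compounds changed only the carbonyl-linked end group, so this is the first reading of a change on the shared core, and here the core tolerates one added carbon. Nothing measured here explains this result. As far as these compounds go, whether a longer chain such as ethyl, or an amine, would be tolerated at this position stays open. So does whether methyl here would behave alike with the end groups of compound 1 and compound 3.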